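Chloro on the benzyl ring of an aortic alpha-1D antagonist

The source may report more compounds than this note shows. Statements on the series, on what has been measured and on what is new or still open speak of the compounds shown alone.

For the measured compounds named here, compound 1 `COc1cccc(OC)c1OCCNCCOc1ccccc1OCc1ccccc1` stands highest of the two numbers known so far: in a functional assay on thoracic aorta for antagonist activity at Alpha-1D adrenergic receptor (Rattus norvegicus) (a lower number here means a less potent compound, a higher number a more potent compound, by a factor of ten per unit of this negative logarithm), compound 1 gives 9.37, while compound 2 `COc1cccc(OC)c1OCCNCCOc1ccccc1OCc1ccccc1Cl` gives 8.59. Going by the values given here, the one measured step, a number 0.78 log units lower from compound 1 to compound 2 (beyond the scatter), shows that a chlorine on that ring can cost potency. Compound 3 `COc1cccc(OC)c1OCCNCCOc1ccccc1OCc1cccc(Cl)c1` carries the change (chloro in place of hydrogen on an aromatic carbon). Because a number 0.78 log units lower from compound 1 to compound 2 (beyond the scatter) is the only bearing on it, a moderate drop is expected, a number 0.47 log units lower from compound 1 to compound 3 (beyond the scatter), though the different placing leaves this uncertain. Compound 3 is therefore estimated at 8.9, likely between 8.3 and 9.5.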

Compound 3, negative logarithm of the antagonist equilibrium constant: 8.72
The estimate for compound 3 lay 0.18 log units above the measured number, within the range that was stated.
By their numbers in this assay, from the lowest: compounds 2 and 3 (each within the scatter of the next); then compound 1.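

In this assay, the 3-chlorobenzyl group also falls short of the plain benzyl group, with a number 0.65 log units lower from compound 1 to compound 3 (beyond the scatter) as the step, so the loss seen with compound 2 is not tied to a single placing of chloro on this ring. With a number 0.13 log units higher from compound 2 to compound 3 (within the scatter) as the step between the two chlorinated compounds, their placings cannot be told apart.

Whether a methoxy group, a fluoro group or an amine on this ring would bring the same loss remains open, and no measurement at hand explains the loss itself.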